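The compounds below may be only part of what the source reports. "The series", "measured", "known", "first", "only" and "open" are said of these compounds alone.

Compound 1, `COc1ccc(F)cc1CNCCCNc1ccnc2cc(CCC(C)C)ccc12`, and compound 2, `COc1ccc(F)cc1CNCCCNc1ccnc2cc(-c3ccc(C(C)(C)C)cc3)ccc12`, share one core and differ only in the group carried on an aromatic carbon of that core. In a physicochemical assay for acid dissociation, compound 1 gives 9.47, and in this assay compound 2 gives 9.47. The step of no change at the digits printed from compound 1 to compound 2 (within the scatter) shows that exchanging isopentyl for 4-(tert-butyl)phenyl left the readiness to give up the proton unchanged within the scatter. Within the data shown here, on the numbers at hand, compound 2 stands level with compound 1, and no further measured compound exists to set beside it.

Compound 3, `COc1ccc(F)cc1CNCCCNc1ccnc2cc(-c3cccc4ccccc34)ccc12`, has not been measured. Its structural change is naphthalen-1-yl in place of 4-(tert-butyl)phenyl on an aromatic carbon. Among the measured compounds shown here, the only measured step that bears on this change is no change at the digits printed from compound 1 to compound 2 (within the scatter), which likewise exchanged the group on that aromatic carbon and produced no change beyond the scatter. For compound 3 the step expected on that basis is a number 0.02 log units lower from compound 2 to compound 3 (within the scatter), that is, none beyond the scatter. Compound 3 is therefore estimated at 9.45, with a range from 9.15 to 9.75.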

Compound 3, acid dissociation constant: 9.47
Beside the measured number, compound 3's estimate is 0.02 log units below it; the range from low to high includes it.
By their numbers in this assay, from the lowest: compounds 1, 2 and 3 (each within the scatter of the next).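

Results in this assay show no change at the digits printed from compound 2 to compound 3 (within the scatter) when naphthalen-1-yl replaces 4-(tert-butyl)phenyl on this aromatic carbon, and no change at the digits printed from compound 1 to compound 3 (within the scatter) when it replaces isopentyl. The earlier pair set only an open chain against a single aromatic ring bearing a tert-butyl group, whereas this result adds a group with two six-membered aromatic rings of carbon only, so three quite different shapes of carbon group now sit at this position with no separation in the read-out. Nothing available here offers an explanation for this sameness.

As far as these compounds go, all three groups are built from carbon and hydrogen alone, so it remains open whether an amine, a carboxylic acid or a pyridine ring on this same carbon would move the number beyond the scatter. Also open, from the compounds shown here alone, is whether a change made elsewhere on the shared core, rather than at this position, would leave the number just as level.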